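Adding methoxy to a compound at the assay limit

The source may hold more compounds than are shown below. What is called first, only, known or untested is meant among the compounds shown, and "the series" means these compounds.

In an ADME assay on Raji cells (Homo sapiens) for cytotoxicity, read by luminescence, with a stated time of 72 h (a lower number here means that less compound is needed, a higher number that more compound is needed for the effect), compound 2 (`CCOC(=O)c1c(-c2cccc(F)c2)[nH]c2cc(OC)c(F)cc2c1=O`) gives > 21500 nM, which is only a limit and not a number. Compound 3 (`CCOC(=O)c1c(-c2cc(F)cc(OC)c2)[nH]c2cc(OC)c(F)cc2c1=O`) differs from it by methoxy in place of hydrogen on an aromatic carbon, which turns 3-fluorophenyl into 3-fluoro-5-methoxyphenyl: methoxy in place of hydrogen on an aromatic carbon. Compound 1 (`CCOC(=O)c1c(-c2cc(F)cc(OC)c2)[nH]c2cc(OC)ccc2c1=O`) already carries 3-fluoro-5-methoxyphenyl on a related core and gives > 21500 nM, again only a limit. The expected step, a step that the limit leaves unreadable from compound 2 to compound 3, is estimated to stay within the scatter, in no particular direction. For compound 3 the estimated value in this assay is 24000 nM, with an expected range from 10000 nM to 60000 nM.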

Compound 3, half-maximal effective concentration: > 21500 nM
Compound 3: a limit, no number; the forecaster's own chance of this, stated with the estimate: 85%; the middle value is on the limit's open side.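

No step to compound 3 can be read from compound 1 or compound 2, since all three compounds stop at a limit in this assay: the limit of > 21500 nM in this assay, at which 3 of the 3 values shown sit.

The compounds shown leave open where each one's actual value lies, and whether either the methoxy or the fluoro exchange changes it at all.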